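Extending the chain on compound 3

A few compounds are considered here, and "the series" means these few. Any claim that something is new, unique, unknown or untested is made for them only; others in the source may bear on it.

Of the compounds shown here, three have been measured in an assay on HEK293 cells for inhibition of solute carrier family 12 member 2 (Homo sapiens), read by fluorescence, with a stated time of 30 min, tested at 100 uM; on this read-out lower numbers stand for a weaker effect and higher numbers for a stronger effect at the one concentration tested. Compound 1, `CCCCNc1ccc([N+](=O)[O-])cc1S(=O)(=O)NC`, gives 13.3%. Compound 2, `CCCCCCCCNc1ccc(C(=O)O)cc1S(N)(=O)=O`, gives 24%. Compound 3, `CCCCNc1ccc(C(=O)O)cc1S(=O)(=O)NC`, gives 6.2%. On these numbers compound 3 stands lowest of the three: its nearest neighbour is compound 1, with a number 7.1 percentage points lower from compound 1 to compound 3 (within the scatter), a step within the scatter, while compound 2 stands furthest from it, beyond the scatter.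

Compound 4, `CCCCCCCCNc1ccc(C(=O)O)cc1S(=O)(=O)NC`, differs from compound 3 in one place: butyl in place of hydrogen on a saturated chain carbon, four bonds along the chain from a nitrogen on an aromatic ring. Among the compounds with values here, no measured step covers this change by itself. Within the data shown here, the one measured step, between compound 1 and compound 3, concerns the group on the aromatic carbon and stays within the scatter, so it carries no information on the chain. Among the measured compounds shown here, compound 2 and compound 3 differ in two places, the chain and the substitution on the sulfonamide, so their two values show only that the octyl-bearing compound 2 sits higher than compound 3, without telling which change is responsible.

Compound 4 is therefore expected to sit near compound 3, with at most a modest rise in this assay, amounting to a number 7.8 percentage points higher from compound 3 to compound 4 (within the scatter). Compound 4 is estimated at 14%, with a range from 4% to 28%.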

Compound 4, a percentage reported as inhibition, at one concentration (the size of the read-out at that concentration, not a potency): 20.1%
Compound 4: the middle estimate sits 6.1 percentage points below what was measured; low and high end bracket the measured number.
By their numbers in this assay, from the lowest: compounds 3, 1, 4 and 2 (each within the scatter of the next, the first and the last beyond it).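

In this assay, butyl in place of hydrogen on a saturated chain carbon, four bonds along the chain from a nitrogen on an aromatic ring, gives a number 13.9 percentage points higher from compound 3 to compound 4 (beyond the scatter) and so isolates a change in the chain that moves the number beyond the scatter, something the two-place difference between compound 2 and compound 3 could not show. The new compound also isolates methyl in place of hydrogen on a sulfonamide nitrogen, which gives a number 3.9 percentage points lower from compound 2 to compound 4 (within the scatter) and thus no readable change in the presence of the octyl chain, though this says nothing of the same swap on the shorter chain. Nothing measured here accounts for the effect of the chain on this read-out.

Going by these compounds, whether the number keeps climbing with a decyl or dodecyl chain, or instead levels off, remains open, as does the result of ending the chain in a phenyl ring or a terminal amine. Also open, on these data alone, is whether a tetrazole in place of the carboxylic acid on the octyl compounds would leave the number where it stands.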